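Removing the Ring Methyl from Compound 3's Piperazine

The source may report more compounds than this note shows. Statements on the series, on what has been measured and on what is new or still open speak of the compounds shown alone.

Compound 1 `CCCn1c(=O)[nH]c2nc(-c3ccc(S(=O)(=O)N4CCN(c5ccccc5C)CC4)cc3)[nH]c2c1=O` gives 0.432 nM in an assay on CHO cells for displacement of a labelled ligand from adenosine receptor A2b (Homo sapiens), read by scintillation counting, with a stated time of 75 min, in the presence of a further agent that is not named here; a higher number here means a weaker inhibitor, a lower number a stronger inhibitor. Compound 2 `CCCn1c(=O)[nH]c2nc(-c3ccc(S(=O)(=O)N4CCN(c5ccc(C)cc5)CC4)cc3)[nH]c2c1=O` gives 0.706 nM. Compound 3 `CCCn1c(=O)[nH]c2nc(-c3ccc(S(=O)(=O)N4CCN(c5ccccc5)C(C)C4)cc3)[nH]c2c1=O` gives 7.15 nM.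

Compound 3 gives the highest number of the three, the step up from compound 2 to compound 3 lying beyond the scatter. Compound 4 `CCCn1c(=O)[nH]c2nc(-c3ccc(S(=O)(=O)N4CCN(c5ccccc5)CC4)cc3)[nH]c2c1=O` differs from compound 3 by hydrogen in place of methyl on a saturated ring carbon. Among the measured compounds shown here, no measured step covers this change; the only single step, a 1.6-fold higher number from compound 1 to compound 2 (0.21 log units; within the scatter), moves a methyl group on the phenyl and stays within the scatter. Compound 4 shares with compound 2 an unsubstituted ring carbon, so a number near that of compound 2 is expected, that is a step of a 7.2-fold lower number from compound 3 to compound 4 (0.85 log units; beyond the scatter). Compound 4 is therefore estimated at 1 nM, with a range from 0.3 nM to 4 nM.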

Compound 4, inhibition constant: 0.643 nM
The estimate for compound 4 lay 1.6-fold (0.19 log units) above the measured number, and the stated range covers the measured number.
By their numbers in this assay, from the lowest: compounds 1, 4 and 2 (each within the scatter of the next); then compound 3.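

On a saturated ring carbon, a single methyl makes a large difference: hydrogen in its place gives an 11-fold lower number from compound 3 to compound 4 (1.05 log units; beyond the scatter). On an aromatic carbon of the phenyl group, the same exchange gives a 1.1-fold lower number from compound 2 to compound 4 (0.04 log units; within the scatter) and a 1.5-fold higher number from compound 1 to compound 4 (0.17 log units; within the scatter), both within the scatter, so among these compounds only the methyl on the saturated ring carbon separates one compound from the rest. Nothing available here gives a reason for this difference.

On these data alone, it remains open whether an ethyl or a hydroxymethyl group on that ring carbon would raise the number as methyl does. As far as these compounds go, it is also open whether a methyl on another saturated ring carbon would do the same.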